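Ring contraction on the amide of compound 2

The compounds below may be only part of what the source reports. "The series", "measured", "known", "first", "only" and "open" are said of these compounds alone.

Compound 2 `COc1ccc(-n2nc(Sc3ccc(Cl)cc3)cc(CCCNC(=O)[C@H]3CCNC[C@@H]3c3ccccc3)c2=O)cc1` holds the higher of the two numbers in an assay on CHO cells with Melanocortin receptor 4 (Homo sapiens) as the target; a lower number here means a stronger inhibitor, a higher number a weaker inhibitor: compound 2 gives 2760 nM, whereas compound 1 `COc1ccc(-n2nc(Sc3ccc(Cl)cc3)cc(CCC(=O)N[C@@H]3CCc4ccccc4NC3=O)c2=O)cc1` gives 144 nM; these two differ in more than one place, so the gap is simply recorded. Compound 3 `COc1ccc(-n2nc(Sc3ccc(Cl)cc3)cc(CCCNC(=O)[C@H]3CNC[C@@H]3c3ccccc3)c2=O)cc1` carries 4-phenylpyrrolidin-3-yl in place of 3-phenylpiperidin-4-yl on a carbonyl carbon. Among the measured compounds shown here, no measured pair shows this change, so its size is open; a step near the scatter in either direction seems plausible, with no firm lean. Compound 3 is estimated at 2500 nM (range 800 nM to 8000 nM) in this assay. The expected step of a 1.1-fold lower number from compound 2 to compound 3 (0.04 log units; within the scatter) is accordingly small.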

Compound 3, half-maximal inhibitory concentration: 1250 nM
Compound 3: the middle estimate sits 2.0-fold (0.30 log units) above what was measured, within the range that was stated.
By their numbers in this assay, from the lowest: compound 1; then compound 3; then compound 2.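

Here is the first single-place step in the series: 4-phenylpyrrolidin-3-yl in place of 3-phenylpiperidin-4-yl on a carbonyl carbon gives a modest gain in this assay (a 2.2-fold lower number from compound 2 to compound 3 (0.34 log units; beyond the scatter)), so the number at this position responds to a change of ring size. Nothing on hand accounts for the step.

From the compounds shown here alone, whether an azetidine ring or an open-chain amine on the same carbonyl carbon would extend this gain stays open. So does the effect of a substituent such as fluorine or methoxy on the phenyl ring.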